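The source may report more compounds than this note shows. Statements on the series, on what has been measured and on what is new or still open speak of the compounds shown alone.

For the measured compounds named here, in a functional assay on the whole organism with Rattus norvegicus as the target, at a dose of 25 mg/kg by the intravenous route (on this read-out higher numbers stand for an effect only at larger amounts of compound and lower numbers for an effect already at smaller amounts), three compounds built on a shared core have numbers so far. Compound 1 (`CCCCc1ccc(C(=O)Nc2cc(C(=O)O)cc(C(=O)O)c2)cc1`) gives 12.3 mg/kg and compound 2 (`O=C(O)c1cc(NC(=O)c2ccc([N+](=O)[O-])cc2)cc(C(=O)O)c1`) gives 9.8 mg/kg and these two values lie within the scatter of each other. Compound 3 (`O=C(O)c1ccc(C(=O)Nc2cc(C(=O)O)cc(C(=O)O)c2)cc1`) stands lowest of the three at 2.1 mg/kg and is clear of both neighbours. The next compound, compound 4 (`N#Cc1ccc(C(=O)Nc2cc(C(=O)O)cc(C(=O)O)c2)cc1`), carries cyano in place of carboxy on an aromatic carbon, para to a large group (cyano in place of carboxy on an aromatic carbon). Going by the values given here, no cyano compound has been measured, so the nearest evidence comes from the steps that install the same carboxy. Nitro to carboxy gave a 4.7-fold lower number from compound 2 to compound 3 (0.67 log units; beyond the scatter) and butyl to carboxy gave a 5.9-fold lower number from compound 1 to compound 3 (0.77 log units; beyond the scatter) whereas butyl to nitro gave only a 1.3-fold lower number from compound 1 to compound 2 (0.10 log units; within the scatter). Read in reverse, these steps suggest that losing the carboxy should cost a modest step in this assay toward a higher number. The expected change is a 3.8-fold higher number from compound 3 to compound 4 (0.58 log units; beyond the scatter) with some uncertainty about its size. For compound 4 the estimated value is 8 mg/kg with an expected range from 3.5 mg/kg to 18 mg/kg.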

Compound 4, dose for 50% inhibition: 1.7 mg/kg
Beside the measured number, compound 4's estimate is 4.7-fold (0.67 log units) above it; measured number below the stated range.
By their numbers in this assay, from the lowest: compounds 4 and 3 (each within the scatter of the next); then compounds 2 and 1 (each within the scatter of the next).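

In this assay, carboxy on this aromatic carbon, para to a large group, gives way to cyano with a 1.2-fold lower number from compound 3 to compound 4 (0.09 log units; within the scatter), so the hydrogen-bond donor of carboxy is not needed to keep the number this low. The earlier compounds shown here could not show this, since until now only carboxy had reached such a number, while cyano also stands clear of the other two groups at this position, with a 5.8-fold lower number from compound 2 to compound 4 (0.76 log units; beyond the scatter) and a 7.2-fold lower number from compound 1 to compound 4 (0.86 log units; beyond the scatter). Nothing available explains why cyano matches carboxy here and not nitro.

Going by these compounds, whether an amine, a chlorine atom or a tetrazole at this position would join compounds 3 and 4 or compounds 1 and 2 remains open. So does whether the match between cyano and carboxy would survive a change to the carboxy groups that all four compounds keep on the shared core.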